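Dropping the bromobenzoyl group from compound 3

The source may hold more compounds than are shown below. What is called first, only, known or untested is meant among the compounds shown, and "the series" means these compounds.

Compound 1 `COc1cc(C2CC(=NOC(=O)c3cccc(O)c3)CC(c3ccc(O)c(OC)c3)N2C)ccc1O`: 25300 nM
Compound 2 `COc1cc(C2CC(=NOC(=O)c3ccc(O)cc3)CC(c3ccc(O)c(OC)c3)N2C)ccc1O`: 22500 nM
Compound 3 `COc1cc(C2CC(=NOC(=O)c3ccc(Br)cc3)CC(c3ccc(O)c(OC)c3)N2C)ccc1O`: 112000 nM
Compound 4 `COc1cc(C2CC(=NO)CC(c3ccc(O)c(OC)c3)N2C)ccc1O`: not yet measured

In a functional assay on microsomes from liver (Rattus norvegicus, strain Wistar) for inhibition, read by spectrophotometry, with a stated time of 60 min (a lower number here means a stronger inhibitor, a higher number a weaker inhibitor), compound 3 has the highest number of the three, 112000 nM, which makes it the weakest inhibitor among them. Compound 4 differs from it by a single change: hydrogen in place of (4-bromophenyl)carbonyl on an oxygen. In words, this is hydrogen in place of (4-bromophenyl)carbonyl on an oxygen.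

Among the measured compounds shown here, no measured step removes this whole group, so the evidence is indirect. Exchanging the group on the carbonyl carbon gives a 4.4-fold higher number from compound 1 to compound 3 (0.65 log units; beyond the scatter) and a 5.0-fold higher number from compound 2 to compound 3 (0.70 log units; beyond the scatter). Both are modest and beyond the scatter. By contrast, a 1.1-fold lower number from compound 1 to compound 2 (0.05 log units; within the scatter) stays within it. Only compound 3 carries the 4-bromophenyl, so losing that group may bring the number down towards compound 2 at 22500 nM. However, compound 4 also lacks the hydroxyphenyl of compound 2, so the size of the change remains uncertain.

The expected step is a 2.2-fold lower number from compound 3 to compound 4 (0.35 log units; beyond the scatter), a modest move towards stronger inhibition. For compound 4 the estimated value is 50000 nM, with an expected range from 15000 nM to 150000 nM.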

Compound 4, half-maximal inhibitory concentration: 167000 nM
Compound 4: middle estimate off by 3.3-fold (0.52 log units), on the low side; the measured number lies above the stated range.
By their numbers in this assay, from the lowest: compounds 2 and 1 (each within the scatter of the next); then compounds 3 and 4 (each within the scatter of the next).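

In this assay, hydrogen in place of (4-bromophenyl)carbonyl on the oxygen gives a 1.5-fold higher number from compound 3 to compound 4 (0.17 log units; within the scatter), so these two compounds cannot be told apart. The hydroxylated groups behave differently: hydrogen in place of (4-hydroxyphenyl)carbonyl gives a 7.4-fold higher number from compound 2 to compound 4 (0.87 log units; beyond the scatter), and hydrogen in place of (3-hydroxyphenyl)carbonyl gives a 6.6-fold higher number from compound 1 to compound 4 (0.82 log units; beyond the scatter), so a carbonyl group on this oxygen goes with a lower number only in compound 1 and compound 2, while compound 3 goes against that pattern. The data offer no measured explanation for this difference.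

As far as these compounds go, it remains open whether a plain phenyl or a 4-aminophenyl on the carbonyl would side with the hydroxyphenyl compounds or with the bromophenyl compound. A simple acetyl group or a longer alkyl chain on this oxygen is also an open case.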